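Methoxy to Allyloxy on a Shared Core

The compounds below may be only part of what the source reports. "The series", "measured", "known", "first", "only" and "open" are said of these compounds alone.

In a functional assay on the whole organism (strain Sprague-Dawley) for inhibition, with Rattus norvegicus as the target, with a stated time of 10 min (on this read-out higher numbers stand for an effect only at larger amounts of compound and lower numbers for an effect already at smaller amounts), compound 1 `COc1ccccc1-c1ncc(C(=O)O)c(=O)[nH]1` gives 10 mg/kg and compound 2 `CCOC(=O)c1cnc(-c2ccccc2O)[nH]c1=O` gives 5 mg/kg while compound 3 `CCOC(=O)c1cnc(-c2ccccc2OC)[nH]c1=O` stands at 10 mg/kg on the same scale, level with compound 1 and within the usual scatter of compound 2. The move to compound 4 `C=CCOc1ccccc1-c1ncc(C(=O)OCC)c(=O)[nH]1` is vinyl in place of hydrogen on a saturated chain carbon bound to an oxygen on an aromatic ring and reads as vinyl in place of hydrogen on a saturated chain carbon bound to an oxygen on an aromatic ring, or methoxy to allyloxy. Methyl placed on that oxygen gave a 2.0-fold higher number from compound 2 to compound 3 (0.30 log units; within the scatter) and ethyl added elsewhere gave no change at the digits printed from compound 1 to compound 3 (within the scatter) in the same test. Within the data shown here, no measured compound carries a longer chain on that oxygen. The expected step is therefore a 1.3-fold lower number from compound 3 to compound 4 (0.10 log units; within the scatter) and nothing beyond the scatter. Compound 4 is estimated at 8 mg/kg and expected to fall between 3 mg/kg and 20 mg/kg.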

Compound 4, dose for 50% inhibition: 0.5 mg/kg
Beside the measured number, compound 4's estimate is 16-fold (1.20 log units) above it; measured number below the stated range.
By their numbers in this assay, from the lowest: compound 4; then compounds 2, 1 and 3 (each within the scatter of the next).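

In this assay the allyl group on the oxygen on the aromatic ring gives a 20-fold lower number from compound 3 to compound 4 (1.30 log units; beyond the scatter) and a 10-fold lower number from compound 2 to compound 4 (1.00 log units; beyond the scatter) while methyl at that same oxygen stayed within the scatter. This position therefore responds strongly to the choice of group, which compounds 1, 2 and 3 alone gave no sign of.

As far as these compounds go, whether a saturated propyl chain, a longer chain or a benzyl group on that oxygen would do the same stays open, as does the effect of allyl alongside a carboxylic acid in place of the ethyl ester. Nothing among the data shown explains why allyl gives this result.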